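Changing one side group on compound 2

The compounds below may be only part of what the source reports. "The series", "measured", "known", "first", "only" and "open" are said of these compounds alone.

In a functional assay on A549 cells (Homo sapiens) for cytotoxicity, read by MTT assay, with a stated time of 72 h (a higher number here means a weaker inhibitor, a lower number a stronger inhibitor), compound 1 `CN(C)CCCCCn1c2c(c3ccccc31)C(=O)c1c[n+]([O-])c3ccccc3c1C2=O` gives 210 nM and compound 2 `CC1(C)OCC(Cn2cc(Cn3c4c(c5ccccc53)C(=O)c3c[n+]([O-])c5ccccc5c3C4=O)nn2)O1` gives 80 nM as the lower of the two numbers, a gap beyond the usual scatter. Compound 3 `O=C1c2c[n+]([O-])c3ccccc3c2C(=O)c2c1c1ccccc1n2Cc1cn(CC(O)CO)nn1` carries one change from compound 2 1,2-dihydroxyethyl in place of 2,2-dimethyl-1,3-dioxolan-4-yl on a saturated chain carbon bound to an aromatic nitrogen in which 1,2-dihydroxyethyl stands in place of 2,2-dimethyl-1,3-dioxolan-4-yl on a saturated chain carbon bound to an aromatic nitrogen. Among the compounds with values here, no measured pair shows this change, so its size is uncertain. In this assay a small rise, probably within the scatter, is expected, and the estimated step runs a 1.5-fold higher number from compound 2 to compound 3 (0.18 log units; within the scatter) toward a higher number. For compound 3 the estimate is 120 nM (expected range 45 nM to 320 nM).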

Compound 3, half-maximal inhibitory concentration: 880 nM
Compound 3: the middle estimate sits 7.3-fold (0.87 log units) below what was measured; the whole stated range lies below it.
By their numbers in this assay, from the lowest: compound 2; then compound 1; then compound 3.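

In this assay, this place on a saturated chain carbon bound to an aromatic nitrogen proves sensitive: 1,2-dihydroxyethyl in place of 2,2-dimethyl-1,3-dioxolan-4-yl gives an 11-fold higher number from compound 2 to compound 3 (1.04 log units; beyond the scatter) as the ring goes and 2 hydrogen-bond donors arrive. Putting 1-(2,3-dihydroxypropyl)-1H-1,2,3-triazol-4-yl in place of 4-(dimethylamino)butyl gives a 4.2-fold higher number from compound 1 to compound 3 (0.62 log units; beyond the scatter) as well, leaving compound 3 the weakest of the three. Nothing measured here explains this loss. Still open, from the compounds shown here alone, is whether losing the ring or gaining the free hydroxyl groups matters more. A 2,3-dimethoxypropyl chain, open but without hydroxyl groups, would help separate the two.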